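A few compounds are considered here, and "the series" means these few. Any claim that something is new, unique, unknown or untested is made for them only; others in the source may bear on it.

Of the compounds shown here, three of a shared core have been measured in a functional assay on PANC-1 cells (Homo sapiens) for inhibition, read by MTT assay, with a stated time of 24 h, tested at 10 uM; on this read-out higher numbers stand for more inhibition at the one concentration tested (going by the name of the read-out) and lower numbers for less inhibition. Compound 1 `CC(C)=CCC1Cc2c(OCCCNC(=O)c3cccs3)cc(=O)n(CCCO)c2CC1(C)C` gives 5.6% in this assay. Compound 2 `CC(C)=CCC/C(C)=C/CC1Cc2c(OCCCNC(=O)c3cccs3)cc(=O)n(CCCO)c2CC1(C)C` gives 11.5%, and compound 3 `CC(C)=CCC/C(C)=C/CC1Cc2c(OCCCOc3ccc([N+](=O)[O-])cc3)cc(=O)n(CCCO)c2CC1(C)C` gives 9.8%. Compound 2 stands apart from neither of its neighbours: the step of a number 5.9 percentage points higher from compound 1 to compound 2 (within the scatter) and the step of a number 1.7 percentage points lower from compound 2 to compound 3 (within the scatter) both fall inside the scatter of repeated measurements, so the three numbers cannot be told apart.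

Compound 4 `CC(C)=CCC/C(C)=C/CC1Cc2c(OC(=O)Nc3ccc(Cl)cc3)cc(=O)n(CCCO)c2CC1(C)C` has not yet been measured. It differs from compound 2 in one place: (4-chlorophenyl)carbamoyl in place of 3-(((thiophen-2-yl)carbonyl)amino)propyl on an oxygen on an aromatic ring. The chain that leaves carried a thiophene amide at its end; what enters is a (4-chlorophenyl)carbamoyl group sitting directly on the oxygen on the aromatic ring.

For the measured compounds named here, only one measured step touches the same oxygen. From compound 2 to compound 3 the chain end was swapped for a 4-nitrophenoxy group, and the result moved by a number 1.7 percentage points lower from compound 2 to compound 3 (within the scatter), that is, not at all beyond the scatter. The step from compound 1 to compound 2 concerns a different part of the molecule. Going by the values given here, with a single within-scatter precedent and no example of a carbamoyl group, the expectation is for no step beyond the scatter: the estimated change is a number 1.5 percentage points lower from compound 2 to compound 4 (within the scatter). Compound 4 is therefore expected to give about 10%, with a range from 0% to 25%.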

Compound 4, a percentage reported as inhibition, at one concentration (the size of the read-out at that concentration, not a potency): 4.3%
The estimate for compound 4 lay 5.7 percentage points above the measured number; the range from low to high includes it.
By their numbers in this assay, from the lowest: compounds 4, 1, 3 and 2 (each within the scatter of the next).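

In this assay, putting (4-chlorophenyl)carbamoyl in place of 3-(((thiophen-2-yl)carbonyl)amino)propyl on the oxygen on an aromatic ring gives a number 7.2 percentage points lower from compound 2 to compound 4 (within the scatter), so compound 4 cannot be told apart from compound 2. The earlier step at this oxygen changed only the group at the end of the chain, whereas this one replaces the whole chain, including its thiophene ring and amide, and places a carbamoyl group directly on the oxygen, yet the read-out still does not move beyond the scatter. Nothing available explains this result or shows how either group acts in the cells.

The two changes at this oxygen leave open whether any group placed there can move the number beyond the scatter, so they do not show whether this position matters for inhibition of these cells at the one concentration tested. A propyl chain ending in an amine or a carboxylic acid, or a longer chain carrying the same thiophene amide, would test this position with groups unlike those seen here.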